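Reversing the chalcone linker on the chlorophenyl analogue

A few compounds are considered here, and "the series" means these few. Any claim that something is new, unique, unknown or untested is made for them only; others in the source may bear on it.

Compound 2 `COc1ccc(-c2cc(/C=C/C(=O)c3ccc(Cl)cc3)nc3cc(-c4ccccc4)nn23)cc1OC`: 17100 nM
Compound 1 `COc1ccc(C(=O)/C=C/c2cc(-c3ccc(OC)c(OC)c3)n3nc(-c4ccccc4)cc3n2)cc1OC`: 2600 nM

In a functional assay on MDA-MB-231 cells (Homo sapiens) for antiproliferative activity, read by MTT assay, with a stated time of 24 h (a lower number here means a stronger inhibitor, a higher number a weaker inhibitor), compound 2 gives 17100 nM, the higher of the two numbers measured; its nearest neighbour, compound 1, gives 2600 nM. Going by the values given here, the only measured step, a 6.6-fold higher number from compound 1 to compound 2 (0.82 log units; beyond the scatter), concerns the 4-chlorophenyl in place of 3,4-dimethoxyphenyl on a carbonyl carbon, not the linker itself.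

Compound 3 `COc1ccc(-c2cc(C(=O)/C=C/c3ccc(Cl)cc3)nc3cc(-c4ccccc4)nn23)cc1OC` has the same atoms as compound 2, joined differently: (2-(4-chlorophenyl)ethenyl)carbonyl in place of 2-((4-chlorophenyl)carbonyl)ethenyl on an aromatic carbon. Among the compounds with values here, no measured pair shows this reversal of the carbonyl and ethenyl positions, and compound 1 carries its carbonyl on a different aryl group again, so the measured step gives no direct guide. With the 4-chlorophenyl retained, compound 3 is expected to stay closer to compound 2 than to compound 1, and the step of a 1.7-fold lower number from compound 2 to compound 3 (0.23 log units; within the scatter) is expected to lie at the edge of the scatter, if anywhere. Compound 3 is therefore estimated at 10000 nM, with a range from 3000 nM to 40000 nM, in this assay.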

Compound 3, half-maximal inhibitory concentration: 23700 nM
Estimate against measurement, compound 3: 2.4-fold (0.37 log units) below; the range from low to high includes it.
By their numbers in this assay, from the lowest: compound 1; then compounds 2 and 3 (each within the scatter of the next).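

Compound 3 places (2-(4-chlorophenyl)ethenyl)carbonyl on the aromatic carbon next to the ring nitrogen, where compound 2 carries 2-((4-chlorophenyl)carbonyl)ethenyl, and in this assay this gives a 1.4-fold higher number from compound 2 to compound 3 (0.14 log units; within the scatter). The earlier step changed only the aryl group on the carbonyl, whereas this one holds the 4-chlorophenyl and the rest of the molecule fixed and reverses the carbonyl and ethenyl positions, and for this pair the assay does not separate the two linker orientations. Nothing available bears on why the two isomers read within the scatter of each other.

It remains open whether the same reversal would also leave the reading within the scatter when the aryl group is the 3,4-dimethoxyphenyl of compound 1, the only aryl group shown to go with a number beyond the scatter of compound 2. The compounds shown also leave open whether the two linker orientations would still read alike with a morpholine or a carboxylic acid in place of the chlorine, or with a saturated two-carbon chain in place of the ethenyl.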